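Fluorine on the Acyl-Side Ring of Indole Acrylonitriles

This account rests on a few compounds, and the source may have more. Where it says the series, first, only, none or still open, it means among the compounds named here.

Measured compounds:
compound 1 `COc1ccc2[nH]cc(/C=C(\C#N)C(=O)c3c[nH]c4ccccc34)c2c1`: 6600 nM
compound 2 `N#C/C(=C\c1c[nH]c2cc(F)ccc12)C(=O)c1c[nH]c2cc(F)ccc12`: > 50000 nM
compound 3 `N#C/C(=C\c1c[nH]c2cc(F)ccc12)C(=O)c1c[nH]c2ccccc12`: 17000 nM

In a functional assay on A549 cells (Homo sapiens) for cytotoxicity, read by WST assay, with a stated time of 24 h (on this read-out lower numbers stand for stronger inhibition and higher numbers for weaker inhibition), compound 1 gives 6600 nM and compound 3 gives 17000 nM. For compound 2 the assay reports only a limit, > 50000 nM, as noted in the limit of > 50000 nM in this assay, at which 1 of the 3 values shown sits. The difference between the core of compound 1 and that of compound 3 is not broken down here. Compound 2 differs from compound 3 by one change, (fluoro in place of hydrogen on an aromatic carbon), and that step is an at least 2.9-fold higher number from compound 3 to compound 2 (0.46 log units; beyond the scatter). Compound 4 `COc1ccc2[nH]cc(/C=C(\C#N)C(=O)c3c[nH]c4cc(F)ccc34)c2c1` is not yet measured; it differs from compound 1 by the same change, (fluoro in place of hydrogen on an aromatic carbon). Given the step from compound 3 to compound 2 in this assay, compound 4 is expected to give a weaker value than compound 1, by about a 2.9-fold higher number from compound 1 to compound 4 (0.46 log units; beyond the scatter). The estimate for compound 4 in this assay is 19000 nM, within 8000 nM to 50000 nM.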

Compound 4, half-maximal inhibitory concentration: 18000 nM
Compound 4: middle estimate off by 1.1-fold (0.02 log units), on the high side, and the stated range covers the measured number.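

In this assay, fluoro in place of hydrogen on an aromatic carbon again goes with a weaker value, a 2.7-fold higher number from compound 1 to compound 4 (0.44 log units; beyond the scatter). Set beside the earlier step, the two read as follows: the same change on two cores in this assay, an at least 2.9-fold higher number (0.46 log units; beyond the scatter) from compound 3 to compound 2 and a 2.7-fold higher number (0.44 log units; beyond the scatter) from compound 1 to compound 4; the limit leaves it open whether they differ. The change thus points the same way on both cores, but this does not show that its size carries over, and two cores establish no rule for the rest of the series.

The compounds shown leave open whether a chloro or an amine in place of this fluoro would move the value the same way. They also leave open whether the step would persist on a core bearing a carboxylic acid.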